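Anilino Swapped for Benzimidazolyl: What Compound 3 Might Show

The source may hold more compounds than are shown below. What is called first, only, known or untested is meant among the compounds shown, and "the series" means these compounds.

Compound 2 `O=c1cc(/C=N\Nc2ccccc2)c2ccc(OCc3ccccc3)cc2o1` was run in a functional assay, read by spectrophotometry, with a stated time of 5 min (on this read-out higher numbers stand for weaker inhibition and lower numbers for stronger inhibition), together with compound 1 `O=c1cc(/C=N\c2ccccc2O)c2ccc(OCc3ccccc3)cc2o1`. In this assay compound 1 gives 469000 nM, while compound 2 gives 416000 nM. The step of a 1.1-fold lower number from compound 1 to compound 2 (0.05 log units; within the scatter) stays within the scatter, so the two numbers cannot be ranked; compound 2 merely holds the lower of the two values by a margin the scatter covers.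

Compound 3 `O=c1cc(-c2nc3ccccc3[nH]2)c2ccc(OCc3ccccc3)cc2o1` differs from compound 2 in one place: a group of 9 heavy atoms (7 carbon, 2 nitrogen; one five-membered aromatic ring with 2 hetero atoms, one six-membered aromatic ring of carbon only) in place of a group of 9 heavy atoms (7 carbon, 2 nitrogen; one six-membered aromatic ring of carbon only), on an aromatic carbon. Going by the values given here, no measured step involves 1H-benzimidazol-2-yl, and the only step available concerns a part that is here removed altogether, so nothing measured bears directly on this change. Compound 3 is therefore expected to give a number near that of compound 2, estimated at 350000 nM with a range from 70000 nM to 1800000 nM. That estimate means an expected step of a 1.2-fold lower number from compound 2 to compound 3 (0.08 log units; within the scatter), not beyond the scatter in either direction.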

Compound 3, half-maximal inhibitory concentration: 146000 nM
The estimate for compound 3 lay 2.4-fold (0.38 log units) above the measured number; low and high end bracket the measured number.
By their numbers in this assay, from the lowest: compound 3; then compounds 2 and 1 (each within the scatter of the next).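

In this assay, 1H-benzimidazol-2-yl on the aromatic carbon opposite the ring oxygen gives a 2.8-fold lower number from compound 2 to compound 3 (0.45 log units; beyond the scatter) and also a 3.2-fold lower number from compound 1 to compound 3 (0.51 log units; beyond the scatter), so compound 3 stands apart from both earlier compounds, which could not be ranked against each other. This shows that the number does respond to what sits at this position, although modestly, and that a group attached directly through an aromatic ring can replace one carried on a double-bonded nitrogen without any loss. Nothing available here explains the difference.

The compounds shown leave open whether the gain comes from the second ring, from the ring hydrogen-bond donor or from the direct attachment, since these all change together. They also leave open how a much smaller group on this carbon, such as an amine or a carboxylic acid, would compare.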